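The source may report more compounds than this note shows. Statements on the series, on what has been measured and on what is new or still open speak of the compounds shown alone.

Of the compounds shown here, two have numbers so far. Compound 1 `O=C(Nc1nc2ccc(F)cc2s1)c1cn(-c2ccccc2)nc1-c1ccccc1` gives 5570 nM in a functional assay on U-87MG ATCC cells for cytotoxicity against U-87 MG (Homo sapiens), read by MTT assay, with a stated time of 72 h; on this read-out lower numbers stand for stronger inhibition and higher numbers for weaker inhibition. Compound 2 `COc1ccc(-c2nn(-c3ccccc3)cc2C(=O)Nc2nc3ccccc3s2)cc1` gives 11500 nM in this assay, the higher of the two numbers, a difference from compound 1 that lies beyond the usual scatter. Compound 1 and compound 2 differ in two places at once, so neither number can be read as the effect of a single change.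

Compound 3 `COc1ccc(-c2nn(-c3ccccc3)cc2C(=O)Nc2nc3ccc(F)cc3s2)cc1` is not yet measured. It differs from compound 2 in one place: fluoro in place of hydrogen on an aromatic carbon. For the measured compounds named here, no measured pair in this set shows this single change on its own, so the size of the step can only be guessed. From compound 2 to compound 3 a small step toward a lower number is expected, a 1.6-fold lower number from compound 2 to compound 3 (0.22 log units; within the scatter), within or just beyond the scatter. Compound 3 is therefore estimated at 7000 nM, with a likely range from 3000 nM to 17000 nM.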

Compound 3, half-maximal inhibitory concentration: 8990 nM
Beside the measured number, compound 3's estimate is 1.3-fold (0.11 log units) below it; the measured number falls inside the stated range.
By their numbers in this assay, from the lowest: compounds 1, 3 and 2 (each within the scatter of the next, the first and the last beyond it).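

In this assay, the change from 1,3-benzothiazol-2-yl to 6-fluoro-1,3-benzothiazol-2-yl gives a 1.3-fold lower number from compound 2 to compound 3 (0.11 log units; within the scatter), so fluoro at this position on a methoxy-bearing compound cannot be told apart from ordinary variation between repeat measurements. The second single change now readable, the addition of a methoxy group, gives a 1.6-fold higher number from compound 1 to compound 3 (0.21 log units; within the scatter), so it too stays inside that variation when the fluoro is present. Nothing measured here offers a reason for the size of either step.

On these data alone, whether a different group at the fluoro position, such as an amine, a carboxylic acid or a longer chain, would move the number beyond the scatter remains open. So does whether an ethoxy group in place of the methoxy would do so.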